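This account rests on a few compounds, and the source may have more. Where it says the series, first, only, none or still open, it means among the compounds named here.

Measured compounds:
Compound 1, `CC1(C)[C@H]2CC[C@]1(C)N(Cc1cn(-c3cccc(Cl)c3)nn1)C(=O)C2`, gives 60 nM in a functional assay on HepG2 cells (Homo sapiens) for inhibition, read by MTT assay, with a stated time of 24 h; on this read-out higher numbers stand for weaker inhibition and lower numbers for stronger inhibition.
Compound 2, `CC1(C)[C@H]2CC[C@]1(C)N(Cc1cn(-c3ccccc3Br)nn1)C(=O)C2`, gives 150 nM in this assay.
Compound 3, `COc1cccc(-n2cc(CN3C(=O)C[C@@H]4CC[C@@]3(C)C4(C)C)nn2)c1`, gives 70 nM in this assay.

Compound 3 stands second highest of the three numbers; its nearest neighbour is compound 1, separated by a 1.2-fold higher number from compound 1 to compound 3 (0.07 log units; within the scatter), and compound 2 lies furthest from it, separated by a 2.1-fold lower number from compound 2 to compound 3 (0.33 log units; beyond the scatter). Compound 4, `CC1(C)[C@H]2CC[C@]1(C)N(Cc1cn(-c3ccc(O)cc3)nn1)C(=O)C2`, has not yet been measured. It differs from compound 3 in one place: 4-hydroxyphenyl in place of 3-methoxyphenyl on an aromatic nitrogen. Going by the values given here, two measured steps bear on this change. Swapping one substituent on the phenyl ring for another gave a 1.2-fold higher number from compound 1 to compound 3 (0.07 log units; within the scatter), while changing both the substituent and its position gave a 2.1-fold lower number from compound 2 to compound 3 (0.33 log units; beyond the scatter). Among the compounds with values here, no measured step introduces a hydroxyl, so the hydrogen-bond donor is untested. Only a small shift is therefore expected, and the number for compound 4 is estimated at 90 nM (range 40 nM to 220 nM). This is expected to amount to a 1.3-fold higher number from compound 3 to compound 4 (0.11 log units; within the scatter).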

Compound 4, half-maximal inhibitory concentration: 80 nM
For compound 4 the middle estimate is 1.1-fold (0.05 log units) above the measured one; low and high end bracket the measured number.
By their numbers in this assay, from the lowest: compounds 1, 3, 4 and 2 (each within the scatter of the next, the first and the last beyond it).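

Going by these compounds alone, compound 4 is the first here to carry a hydrogen-bond donor on the phenyl ring, yet its hydroxyl gives a number within the scatter of the methoxy analogue (a 1.1-fold higher number from compound 3 to compound 4 (0.06 log units; within the scatter)). The other two steps also stay within the scatter (a 1.3-fold higher number from compound 1 to compound 4 (0.12 log units; within the scatter) and a 1.9-fold lower number from compound 2 to compound 4 (0.27 log units; within the scatter)), so this ring cannot be told apart from either halogen-bearing ring, although those two differ beyond the scatter. No measurement shown here explains this result.

Group and position change together in this step, so 3-hydroxyphenyl and 4-methoxyphenyl would be needed to separate them. From the compounds shown here alone, how an amine or a carboxylic acid on this ring would read also remains open.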